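This account rests on a few compounds, and the source may have more. Where it says the series, first, only, none or still open, it means among the compounds named here.

Compound 3, `C/C(=N\Nc1nc(-c2ccc(Cl)cc2)cs1)c1sc(-c2ccccc2)nc1C`, is one of three close relatives tested in a toxicity assay on THP-1 cells (Homo sapiens) for cytotoxicity, read by MTT assay; on this read-out lower numbers stand for stronger inhibition of growth and higher numbers for weaker inhibition of growth. In this assay compound 3 reaches only the limit of > 100 ug/mL. Compound 1, `C/C(=N\Nc1nc(-c2ccccc2)cs1)c1sc(-c2ccccc2)nc1C`, likewise gives only the limit of > 100 ug/mL. Compound 2, `C/C(=N\Nc1nc(-c2ccc(F)cc2)cs1)c1sc(-c2ccccc2)nc1C`, gives only the limit of > 100 ug/mL. All three therefore sit at the limit of > 100 ug/mL in this assay, at which 3 of the 3 values shown sit, so the steps from compound 1 to compound 2, a step that the two limits leave unreadable from compound 1 to compound 2, from compound 1 to compound 3, a step that the two limits leave unreadable from compound 1 to compound 3, and from compound 2 to compound 3, a step that the two limits leave unreadable from compound 2 to compound 3, cannot be sized. Compound 4, `C/C(=N\Nc1nc(-c2ccc(Br)cc2)cs1)c1sc(-c2ccccc2)nc1C`, differs from compound 3 by bromo in place of chloro on an aromatic carbon. With no readable step among the three halogen variants, no change beyond the scatter is expected, a step that the limit leaves unreadable from compound 3 to compound 4. Compound 4 is thus estimated at 150 ug/mL, within 60 ug/mL to 400 ug/mL.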

Compound 4, concentration for 50% growth inhibition: 48.9 ug/mL
Beside the measured number, compound 4's estimate is 3.1-fold (0.49 log units) above it; the measured number lies below the stated range.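

In this assay, the para position of this phenyl ring, para to a large group, proves able to move the number, as only the 4-bromophenyl variant gives a value rather than a limit. Bromo gives an at least 2.0-fold lower number from compound 3 to compound 4 (0.31 log units; beyond the scatter), an at least 2.0-fold lower number from compound 2 to compound 4 (0.31 log units; beyond the scatter) and an at least 2.0-fold lower number from compound 1 to compound 4 (0.31 log units; beyond the scatter). These steps are minimum sizes, and those among the other three compounds cannot be read, since all three remain at a limit: the limit of > 100 ug/mL in this assay, at which 3 of the 4 values shown sit.

On these data alone, whether an amine or a methoxy group at this position would give a lower number stays open. So does whether the bromo step would hold on a different core.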